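Three Measured Analogues and One Untested Substitution

The compounds below may be only part of what the source reports. "The series", "measured", "known", "first", "only" and "open" are said of these compounds alone.

Measured compounds: compound 1 `Cc1cc(O)c(C2=NN(c3ccc(S(N)(=O)=O)cc3)C(c3ccccc3O)C2)cc1Cl` gives 3900 nM; compound 2 `Cc1cc(O)c(C2=NN(c3ccc(S(N)(=O)=O)cc3)C(c3ccccc3Cl)C2)cc1Cl` gives 2730 nM; compound 3 `Cc1cc(O)c(C2=NN(c3ccc(S(N)(=O)=O)cc3)C(/C=C/c3ccccc3)C2)cc1Cl` gives 3740 nM.

In a functional assay on OVCAR-4 cells (Homo sapiens) for antiproliferative activity, with a stated time of 48 h (a higher number here means a weaker inhibitor of growth, a lower number a stronger inhibitor of growth), compound 3 stands second highest of the three numbers, its closest neighbour being compound 1 with a 1.0-fold lower number from compound 1 to compound 3 (0.02 log units; within the scatter), its furthest compound 2 with a 1.4-fold higher number from compound 2 to compound 3 (0.14 log units; within the scatter). Compound 4 `COc1ccc(C2CC(c3cc(Cl)c(C)cc3O)=NN2c2ccc(S(N)(=O)=O)cc2)cc1OC` differs from compound 3 in one place: 3,4-dimethoxyphenyl in place of 2-phenylethenyl on a saturated ring carbon. Among the compounds with values here, no measured step exchanges a 2-phenylethenyl for a 3,4-dimethoxyphenyl, but both earlier exchanges at this saturated ring carbon, a 1.0-fold lower number from compound 1 to compound 3 (0.02 log units; within the scatter) and a 1.4-fold higher number from compound 2 to compound 3 (0.14 log units; within the scatter), stayed within the scatter. The step from compound 3 is therefore expected to be a 1.1-fold lower number from compound 3 to compound 4 (0.03 log units; within the scatter), with no change beyond the scatter. Compound 4 is estimated at 3500 nM, in the range 1500 nM to 8000 nM.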

Compound 4, concentration for 50% growth inhibition: 4180 nM
The estimate for compound 4 lay 1.2-fold (0.08 log units) below the measured number; measured number inside the range.
By their numbers in this assay, from the lowest: compounds 2, 3, 1 and 4 (each within the scatter of the next).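

At this saturated ring carbon in this assay, 3,4-dimethoxyphenyl, a group with 2 hydrogen-bond acceptors, leaves the number within the scatter of all three groups it is compared with: a 1.1-fold higher number from compound 3 to compound 4 (0.05 log units; within the scatter) and a 1.5-fold higher number from compound 2 to compound 4 (0.19 log units; within the scatter) and a 1.1-fold higher number from compound 1 to compound 4 (0.03 log units; within the scatter) are all within it. All four groups at this position now stand within the scatter of one another, so this change gives the position no order of preference. Nothing available explains this lack of separation.

Going by these compounds, whether an amine, a carboxylic acid or a longer saturated chain on this carbon would move the number beyond the scatter remains open.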